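The compounds below may be only part of what the source reports. "The series", "measured", "known", "first", "only" and "open" are said of these compounds alone.

Compound 1, `COc1cc2nc(N3CCN(C(=O)OCc4ccccc4)CC3)nc(N)c2cc1OC`, gives 63000 nM in a functional assay on PC-3 cells (Homo sapiens) for inhibition; a higher number here means a weaker inhibitor, a lower number a stronger inhibitor.
Compound 2, `COc1cc2nc(N3CCN(C(=O)c4ccc(C(C)(C)C)cc4)CC3)nc(N)c2cc1OC`, gives 47000 nM in this assay.
Compound 3, `COc1cc2nc(N3CCN(S(=O)(=O)c4ccc(Br)cc4)CC3)nc(N)c2cc1OC`, gives 20000 nM in this assay.

All three share one core and differ only in the group carried by the amine nitrogen in the ring. Compound 3 holds the lowest number of the three: the step of a 3.2-fold lower number from compound 1 to compound 3 (0.50 log units; beyond the scatter) lies beyond the scatter, and the number of compound 3 also sits beyond the scatter below that of compound 2, so in this assay compound 3 is the strongest inhibitor measured so far. The step of a 1.3-fold lower number from compound 1 to compound 2 (0.13 log units; within the scatter), by contrast, changes nothing that can be trusted.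

Compound 4, `COc1cc2nc(N3CCN(S(=O)(=O)c4ccccc4[N+](=O)[O-])CC3)nc(N)c2cc1OC`, keeps the sulfonyl of compound 3 and alters only the ring on it: 2-nitrophenyl in place of 4-bromophenyl on a sulfonyl sulfur. Among the measured compounds shown here, no measured step exchanges one aryl group for another on a sulfonyl sulfur, so there is no direct guide. The closest comparison is a 1.3-fold lower number from compound 1 to compound 2 (0.13 log units; within the scatter), where a different ring on a carbonyl carbon left the number within the scatter. On that basis no step beyond the scatter is expected in this assay, in either direction. The estimate for compound 4 is therefore 25000 nM, with a range from 8000 nM to 80000 nM. The expected step is a 1.3-fold higher number from compound 3 to compound 4 (0.10 log units; within the scatter).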

Compound 4, half-maximal inhibitory concentration: 35000 nM
Estimate against measurement, compound 4: 1.4-fold (0.15 log units) below; the measured number falls inside the stated range.
By their numbers in this assay, from the lowest: compounds 3, 4, 2 and 1 (each within the scatter of the next, the first and the last beyond it).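

In this assay, among the compounds shown here, changing the ring on the sulfonyl sulfur gives a 1.8-fold higher number from compound 3 to compound 4 (0.24 log units; within the scatter), the first measured exchange of one aryl group for another at this place. The 2-nitrophenyl brings in hydrogen-bond acceptors that the 4-bromophenyl lacks and gives up the bromine, yet the two compounds cannot be told apart here, so at this place and in this assay, this one exchange of ring makes no readable difference. No measurement of any property of these compounds is available to account for this result.

The compounds shown do not separate the bromine and the nitro group from the aryl ring that carries them, and a plain phenyl on the sulfonyl sulfur would provide that baseline. They also leave open whether a quite different group on that ring, such as an amine or a carboxylic acid, would move the number beyond the scatter, because a single exchange cannot show how far this place tolerates change.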